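The compounds below may be only part of what the source reports. "The series", "measured", "known", "first", "only" and "open" are said of these compounds alone.

Measured in a functional assay on HL-60 cells (Homo sapiens) for antiproliferative activity, read by MTT assay, with a stated time of 48 h; a lower number here means a stronger inhibitor, a higher number a weaker inhibitor:
- compound 1 `O=c1oc2cc(O)ccc2cc1-c1ccc(O)cc1`: > 200000 nM
- compound 2 `O=c1oc2cc(O)ccc2cc1-c1ccc(O)c(O)c1`: 42100 nM

Compound 1 gives > 200000 nM, which is a limit of the assay and not a number. Any step starting from compound 1 is therefore known only on one side.

Compound 3 `COc1cc2cc(-c3ccc(O)cc3)c(=O)oc2cc1O` differs from compound 1 as follows: methoxy in place of hydrogen on an aromatic carbon. The new methoxy sits on the fused system, ortho to a hydroxy group.

Among the measured compounds shown here, only one measured step bears on this: an at least 4.7-fold lower number from compound 1 to compound 2 (0.67 log units; beyond the scatter). That step adds a hydroxy, a different group at a different place, so it is a loose guide. A move of similar or smaller size towards a lower number is expected in this assay, and compound 3 could also stay at the limit.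

The expected step is an at least 2.2-fold lower number from compound 1 to compound 3 (0.34 log units; beyond the scatter).

Compound 3 is estimated at 90000 nM, with an expected range of 25000 nM to 200000 nM.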

Compound 3, half-maximal inhibitory concentration: 5200 nM
Beside the measured number, compound 3's estimate is 17-fold (1.24 log units) above it; measured number below the stated range.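

In this assay, methoxy in place of hydrogen on an aromatic carbon of the fused system, ortho to a hydroxy group, gives an at least 38-fold lower number from compound 1 to compound 3 (1.58 log units; beyond the scatter). Among the compounds shown here, the only earlier step lay at a different place and involved a hydroxy, so this is the first reading for this position, and it shows that a small ether group here is enough to bring the series well clear of the limit. The step is a lower bound only, because its starting point is a limit of the assay and not a number: the limit of > 200000 nM in this assay, at which 1 of the 3 values shown sits.

On these data alone, whether an ethoxy group, a longer alkoxy chain, a chlorine or an amine at this position would give a similar step remains open. Also open, as far as these compounds go, is whether the methoxy step depends on the hydroxy group ortho to it, and whether it would hold alongside the added hydroxy of compound 2.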